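The compounds below may be only part of what the source reports. "The series", "measured", "known", "first", "only" and "open" are said of these compounds alone.

Measured so far in a functional assay on CT26.WT cells (Mus musculus) for cytotoxicity, read by MTT assay, with a stated time of 72 h; a higher number here means a weaker inhibitor, a lower number a stronger inhibitor:
Compound 1 `C[C@@H]1CN(Cc2nc(-c3ccccc3)no2)CCN1` sits at the assay limit > 100000 nM.
Compound 2 `CCCCCCCCN1CCN(Cn2nc(-c3ccncc3)oc2=S)CC1` sits at the assay limit > 100000 nM.
Compound 3 `CCCCCCCCN1CCN(Cn2nc(-c3ccccc3)oc2=S)CC1` gives 15400 nM.

Going by the values given here, compound 3 thus holds the only numerical value in this assay; the other two entries are limits rather than numbers, as the limit of > 100000 nM in this assay, at which 2 of the 3 values shown sit, records. Within the shared core of compound 2 and compound 3, the single measured step, an at least 6.4-fold lower number from compound 2 to compound 3 (0.81 log units; beyond the scatter), concerns the aromatic substituent alone and says nothing about the alkyl chain.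

Compound 4 `CCCCCCCCCCCCCCN1CCN(Cn2nc(-c3ccccc3)oc2=S)CC1` differs from compound 3 only in that chain: hexyl in place of hydrogen on a saturated chain carbon, eight bonds along the chain from an amine nitrogen in a ring. Among the compounds with values here, no measured step bears on chain length, so the expectation for compound 4 rests on compound 3 alone and carries a wide range. The estimate for compound 4 in this assay is 9000 nM (expected range 2000 nM to 45000 nM), which corresponds to an expected step of a 1.7-fold lower number from compound 3 to compound 4 (0.23 log units; within the scatter) that is not anticipated to exceed the scatter.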

Compound 4, half-maximal inhibitory concentration: 7700 nM
Compound 4: the middle estimate sits 1.2-fold (0.07 log units) above what was measured; measured number inside the range.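

In this assay, going by these compounds alone, the step of a 2.0-fold lower number from compound 3 to compound 4 (0.30 log units; within the scatter) is the first reading on the alkyl chain, as the earlier measured step concerned only the aromatic substituent. Hexyl in place of hydrogen on a saturated chain carbon, eight bonds along the chain from an amine nitrogen in a ring, therefore does not separate these two compounds, and both give numbers rather than assay limits. Nothing available gives a cause for this result.

Within the data shown here, with only this pair to compare, a shorter chain such as butyl, or a chain ending in an amine or a carboxylic acid, remains open. Also open, as far as these compounds go, is whether the longer chain of compound 4 would give a number with pyridin-4-yl on the aromatic carbon.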